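This account rests on a few compounds, and the source may have more. Where it says the series, first, only, none or still open, it means among the compounds named here.

Working notes on the series. The read-out is an assay on membranes from cerebellum for inhibition of Monoglyceride lipase (Rattus norvegicus), tested at 100 uM; on this read-out lower numbers stand for less inhibition and higher numbers for more inhibition at the one concentration tested (going by the name of the read-out). Three compounds have numbers in it. Compound 1 `CCCCC/C=C\C/C=C\C/C=C\C/C=C\CCCC(=O)OC[C@@H]1COC(C)(C)O1` gives 38%. Compound 2 `CCCCCCCC/C=C\CCCCCCCC(=O)OCC1CCCCO1` gives 35%. Compound 3 `O=C(OCC1CO1)c1ccccc1-c1ccccc1` gives 18%, the lowest of the three numbers; the nearest number is that of compound 2, higher by a gap beyond the scatter, and the furthest is that of compound 1, also higher by a gap beyond the scatter. For the measured compounds named here, no two of the measured compounds differ in one place only, so no single-change step within the measured set can be read off.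

Compound 4 `O=C(OCC1CO1)c1ccccc1` is not yet measured in this assay. It differs from compound 3 in one place: hydrogen in place of phenyl on an aromatic carbon.

Expectation. Going by the values given here, compound 3 already sits at the low end of the numbers in this assay, and there is no measured pair in this set to show what the loss of the phenyl does. The step from compound 3 to compound 4 in this assay is expected to be small and, if anything, downward, most likely not beyond the scatter, namely a number 4 percentage points lower from compound 3 to compound 4 (within the scatter). Compound 4 is expected to give about 14% in this assay, within a range of 2% to 30%, because compound 3 gives 18% and the change removes the phenyl only.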

Compound 4, a percentage reported as inhibition, at one concentration (the size of the read-out at that concentration, not a potency): 0.2%
The estimate for compound 4 lay 13.8 percentage points above the measured number; measured number outside the range, below it.
By their numbers in this assay, from the lowest: compound 4; then compound 3; then compounds 2 and 1 (each within the scatter of the next).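

For the compounds shown here, the change of phenyl to hydrogen on an aromatic carbon, ortho to a group of 7 heavy atoms, gives a number 17.8 percentage points lower from compound 3 to compound 4 (beyond the scatter) in this assay, and this is the first single-change step. It shows that the inhibition read at this one concentration is sensitive to what stands at this place: with hydrogen there, compound 4 gives 0.2%, so practically nothing remains of the inhibition seen with phenyl in place. No measurement of any property bears on this step, so the data give no reason for it.

As far as these compounds go, one pair defines only the two ends of this change, and it remains open where a methyl, a methoxy, an amine, a carboxylic acid or a larger aromatic ring at the same place would fall in this assay. Steps linking compound 3 or compound 4 to compound 1 or compound 2 cannot be read, so it also remains open whether the ester chains of those two compounds would respond to any such change in the same way.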